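From Nitro to Diethylamino on the Shared Core

The compounds below may be only part of what the source reports. "The series", "measured", "known", "first", "only" and "open" are said of these compounds alone.

Going by the values given here, compound 2 `COc1cccc(OC)c1C(=O)Nc1nnc(-c2ccc([N+](=O)[O-])cc2)s1` gives 269 nM in a functional assay on the whole organism (integument) for inhibition, with Chilo suppressalis as the target, read by scintillation counting, with a stated time of 72 h, in the presence of a further agent that is not named here (a higher number here means a weaker inhibitor, a lower number a stronger inhibitor), the highest of the two numbers measured so far. Compound 1 `COc1cccc(OC)c1C(=O)Nc1nnc(-c2ccc(Br)cc2)s1` gives 45.7 nM in this assay, and the step of a 5.9-fold higher number from compound 1 to compound 2 (0.77 log units; beyond the scatter) is the only one measured. Compound 3 `CCN(CC)c1ccc(-c2nnc(NC(=O)c3c(OC)cccc3OC)s2)cc1` differs from compound 2 by diethylamino in place of nitro on an aromatic carbon. Among the compounds with values here, no measured step covers this exchange, so the direction rests on the single step known. A modest step toward a lower number is expected, a 2.2-fold lower number from compound 2 to compound 3 (0.35 log units; beyond the scatter), with wide uncertainty. For compound 3 the estimate is 120 nM, within 30 nM to 500 nM.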

Compound 3, half-maximal inhibitory concentration: 676 nM
Estimate against measurement, compound 3: 5.6-fold (0.75 log units) below; the measured number lies above the stated range.
By their numbers in this assay, from the lowest: compound 1; then compound 2; then compound 3.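

In this assay, diethylamino on this aromatic carbon raises the number further than nitro does (a 2.5-fold higher number from compound 2 to compound 3 (0.40 log units; beyond the scatter)), and the gap to bromo is now large (a 15-fold higher number from compound 1 to compound 3 (1.17 log units; beyond the scatter)). Both groups that replace bromo at this place therefore give higher numbers, and bromo remains the lowest of the three. Nothing given here explains these steps. The compounds shown leave open whether another halogen, such as chloro or fluoro, would match bromo. They also leave open how a simple amine or a methoxy group would fare at this place.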